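This account rests on a few compounds, and the source may have more. Where it says the series, first, only, none or still open, it means among the compounds named here.

Measured so far:
compound 1 `CCC(C(=O)N1CCN(c2cccc(F)c2)CC1)N1C(=O)CCC1=O` – 0%
compound 2 `CC(C(=O)N1CCN(c2ccc(F)cc2)CC1)N1C(=O)CCC1=O` – 0%

In a functional assay on the whole organism (strain Swiss) with Mus musculus as the target, in the maximal electroshock model, with a stated time of 2 h, at a dose of 100 mg/kg by the intraperitoneal route (a higher number here means a stronger effect of the compound at the dose given, a lower number a weaker effect), compound 1 gives 0%. In this assay compound 2 gives 0%, level with compound 1 at the digits shown, within the scatter. Compound 3 `CC(C(=O)N1CCN(c2cccc(F)c2)CC1)N1C(=O)CCC1=O` is not yet measured. It differs from compound 2 in one place: 3-fluorophenyl in place of 4-fluorophenyl on an amine nitrogen in a ring. Within the data shown here, no step between measured compounds is available for this change; the only comparison, compound 1 beside compound 2, shows the same value with a different position of the fluorine and a different chain. The expected step for compound 3 in this assay is no change at the digits printed from compound 2 to compound 3 (within the scatter), none beyond the scatter. Compound 3 is estimated at 0%, with a range from 0% to 20%.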

Compound 3, a percentage reported as activity, at one dose (the size of the read-out at that dose, not a potency): 0%
Compound 3: middle estimate and measured number agree at the digits printed; the measured number falls inside the stated range.
By their numbers in this assay, from the lowest: compounds 1, 2 and 3 (each within the scatter of the next).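

In this assay the fluorine position now has a direct reading: moving it gives no change at the digits printed from compound 2 to compound 3 (within the scatter) in the series. Shortening the chain with the 3-fluorophenyl group held constant gives no change at the digits printed from compound 1 to compound 3 (within the scatter) as its result. Neither change separates these compounds, and compound 3 at 0% stays level with both neighbours. Open, as far as these compounds go, is whether a trifluoromethyl or methoxy group on the phenyl ring, or a longer chain, would give any reading at this dose. Nothing available explains the flat result.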